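Methylsulfonyl for methyl on the propanoyl chain of compound 2

This account rests on a few compounds, and the source may have more. Where it says the series, first, only, none or still open, it means among the compounds named here.

Measured so far in an in vitro assay on CHO cells for inhibition of B1 bradykinin receptor (Homo sapiens); on this read-out lower numbers stand for stronger inhibition and higher numbers for weaker inhibition:
compound 1 `Cc1ccnc(NCc2ccc(-c3ccccc3C(=O)O)cc2)c1NC(=O)CC#N`, 11.5 nM
compound 2 `CCC(=O)Nc1cccnc1NCc1ccc(-c2ccccc2C(=O)OC)cc1`, 119 nM
compound 3 `CNC(=O)c1ccccc1-c1ccc(CNc2nccc(C)c2NC(=O)CC(F)(F)F)cc1`, 11 nM

Compound 2 stands at the highest of the three numbers. Compound 1 gives 11.5 nM and compound 3 gives 11 nM; both gaps to compound 2 lie beyond the scatter. Both compounds differ from compound 2 in more than one place, so no single step can be read from them; only the values themselves can be set side by side.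

Compound 4 `COC(=O)c1ccccc1-c1ccc(CNc2ncccc2NC(=O)CS(C)(=O)=O)cc1` is the next point. It differs from compound 2 in one place: methylsulfonyl in place of methyl on a saturated chain carbon bound to a carbonyl carbon. Among the compounds with values here, no measured step of this kind exists. The two compounds with a substituted chain carbon, compound 1 and compound 3, give lower numbers than compound 2, but their other differences leave the attribution open. A moderate step toward a lower number is therefore expected for compound 4, with wide uncertainty: a 3.0-fold lower number from compound 2 to compound 4 (0.47 log units; beyond the scatter). The estimate for compound 4 is 40 nM, within 10 nM to 160 nM.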

Compound 4, inhibition constant: 40 nM
Beside the measured number, compound 4's estimate shows no gap at the digits printed, and the stated range covers the measured number.
By their numbers in this assay, from the lowest: compounds 3 and 1 (each within the scatter of the next); then compound 4; then compound 2.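

In this assay, within the data shown here, the first single-place step is a 3.0-fold lower number from compound 2 to compound 4 (0.47 log units; beyond the scatter), so the saturated chain carbon bound to a carbonyl carbon is a place where the number responds. Methylsulfonyl, with 4 heavy atoms and 2 hydrogen-bond acceptors against 1 heavy atom and no acceptor for methyl, is accepted there, and the number falls rather than rises. Nothing measured here says what lies behind this step.

Steps linking compound 1 or compound 3 to compound 2 or compound 4 cannot be read, since those pairs differ in more than one place. Open at this chain carbon is whether an ethylsulfonyl group, a dimethylamino group or a longer chain would carry the number further, and whether methylsulfonyl gives a similar step on the core of compound 1.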